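Trading a ring for a hydroxylated chain on the amide

The source may report more compounds than this note shows. Statements on the series, on what has been measured and on what is new or still open speak of the compounds shown alone.

Three measured compounds share one core and differ only in the group on the amide nitrogen. Compound 1 `Cc1cc(C(=O)NC(C)(C)C)nn1Cc1cc(Cl)cc2cc(-c3ccccc3)oc12` carries a tert-butyl group there, and in an assay on CHO-K1 cells for displacement of a labelled ligand from prostaglandin E2 receptor EP1 subtype (Homo sapiens), read by scintillation counting, with a stated time of 45 min (on this read-out higher numbers stand for weaker inhibition and lower numbers for stronger inhibition), compound 1 gives 10 nM. Compound 2 `Cc1cc(C(=O)N[C@H]2CC[C@H](O)CC2)nn1Cc1cc(Cl)cc2cc(-c3ccccc3)oc12` carries a 4-hydroxycyclohexyl group, and in this assay compound 2 gives 7.94 nM. Compound 3 `Cc1cc(C(=O)NC[C@H]2CCCO2)nn1Cc1cc(Cl)cc2cc(-c3ccccc3)oc12` carries an (oxolan-2-yl)methyl group, and in this assay compound 3 gives 6.31 nM. Compound 3 stands at the low end of these numbers, but a 1.6-fold lower number from compound 1 to compound 3 (0.20 log units; within the scatter) and a 1.3-fold lower number from compound 2 to compound 3 (0.10 log units; within the scatter) are both within the scatter, as is a 1.3-fold lower number from compound 1 to compound 2 (0.10 log units; within the scatter), so the three cannot be told apart. Compound 4 `Cc1cc(C(=O)NCC(O)C(F)(F)F)nn1Cc1cc(Cl)cc2cc(-c3ccccc3)oc12` is not yet measured; it differs from compound 3 by 2,2,2-trifluoro-1-hydroxyethyl in place of oxolan-2-yl on a saturated chain carbon bound to an amide-type nitrogen. Every step measured so far changes this same amide substituent, and none moved the number beyond the scatter, so the step expected from compound 3 to compound 4 is a 1.3-fold higher number from compound 3 to compound 4 (0.10 log units; within the scatter), that is, none beyond the scatter. Compound 4 is therefore estimated to give 8 nM, within a range of 3 nM to 25 nM, in this assay.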

Compound 4, half-maximal inhibitory concentration: 25.1 nM
Compound 4: the middle estimate sits 3.1-fold (0.50 log units) below what was measured; measured number above the stated range.
By their numbers in this assay, from the lowest: compounds 3, 2 and 1 (each within the scatter of the next); then compound 4.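

In this assay, the amide substituent now makes a difference beyond the scatter, with modest rises in the number on going to the 3,3,3-trifluoro-2-hydroxypropyl group (a 4.0-fold higher number from compound 3 to compound 4 (0.60 log units; beyond the scatter)) (a 3.2-fold higher number from compound 2 to compound 4 (0.50 log units; beyond the scatter)) (a 2.5-fold higher number from compound 1 to compound 4 (0.40 log units; beyond the scatter)). Neither leaving the ring behind nor adding a hydroxyl accounts for this by itself: the tert-butyl group of compound 1 has no ring, and the 4-hydroxycyclohexyl group of compound 2 carries a hydroxyl, yet neither compound is separated from compound 3 by more than the scatter. Nothing available here explains the rise.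

Going by these compounds, the change brings in the hydroxyl and the three fluorine atoms together, so which of them matters stays open. A 2-hydroxypropyl or a 3,3,3-trifluoropropyl group on the same amide-type nitrogen would separate the two.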